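The source may report more compounds than this note shows. Statements on the series, on what has been measured and on what is new or still open speak of the compounds shown alone.

Measured so far:
Compound 1 `COc1ccc(/C=C/C(=O)/C=C/c2cc3ccccc3nc2Oc2ccccc2)c(OC)c1` — in a functional assay on 4T1 cells (Mus musculus) for cytotoxicity, read by MTT assay, with a stated time of 48 h (a higher number here means a weaker inhibitor, a lower number a stronger inhibitor), compound 1 gives > 10000 nM, which is a limit of the assay rather than a number.
Compound 2 `COc1cc(OC)c(/C=C/C(=O)/C=C/c2cc3ccccc3nc2Oc2ccccc2)c(OC)c1` — in this assay compound 2 gives > 10000 nM, again only a limit.
Compound 3 `COc1ccc(/C=C/C(=O)/C=C/c2cc3ccccc3nc2Oc2ccc(Br)cc2)cc1` — in this assay compound 3 gives > 10000 nM, also a limit.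

Compound 2 arises from compound 1 by methoxy in place of hydrogen on an aromatic carbon. Both values sit at the same limit, so the step that the two limits leave unreadable from compound 1 to compound 2 cannot be read, as summed up in the limit of > 10000 nM in this assay, at which 3 of the 3 values shown sit. Compound 3 has a related skeleton, but the difference between the two cores is not broken down here. Compound 4 `COc1ccc(/C=C/C(=O)/C=C/c2cc3ccccc3nc2Oc2ccc(Br)cc2)c(OC)c1` arises from compound 3 by methoxy in place of hydrogen on an aromatic carbon. Going by the values given here, this is the same kind of change as the one from compound 1 to compound 2, though the surroundings differ: here the entering methoxy is meta to a methoxy group, whereas in the earlier pair it is meta to two methoxy groups. For compound 4 the expected step is a step that the limit leaves unreadable from compound 3 to compound 4. That expectation rests on compound 3 giving only a limit, > 10000 nM. It rests as well on the step that the two limits leave unreadable from compound 1 to compound 2 staying unreadable. Compound 4 is therefore estimated at 15000 nM, most likely between 4000 nM and 60000 nM.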

Compound 4, half-maximal inhibitory concentration: > 10000 nM
Compound 4 ended at the assay's limit; the forecaster's own chance of this, stated with the estimate: 80%; the middle value lies beyond the limit too.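

The steps from compound 3 to compound 4 and from compound 1 to compound 4 cannot be read, as every value is a limit: the limit of > 10000 nM in this assay, at which 4 of the 4 values shown sit. The compounds shown leave open whether adding methoxy or bromo changes cytotoxicity at all in this assay.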